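The source may hold more compounds than are shown below. What is called first, only, known or untested is meant among the compounds shown, and "the series" means these compounds.

In a functional assay on the whole organism for antagonist activity, with Mus musculus as the target (on this read-out higher numbers stand for an effect only at larger amounts of compound and lower numbers for an effect already at smaller amounts), three amines on the shared core have been measured. Compound 1 `C=CCNC1CCCC1N(C(=O)CC)c1ccc(Cl)c(Cl)c1` gives 3 mg/kg and compound 2 `CCCN(CCC)C1CCCC1N(C(=O)CC)c1ccc(Cl)c(Cl)c1` gives 0.1 mg/kg while compound 3 `CCC(=O)N(c1ccc(Cl)c(Cl)c1)C1CCCC1N(C)Cc1ccccc1` gives 40 mg/kg as the highest number of the three. Compound 4 `CCC(=O)N(c1ccc(Cl)c(Cl)c1)C1CCCC1N(C)CCN(C)C` differs from compound 3 by one exchange ((dimethylamino)methyl in place of phenyl on a saturated chain carbon bound to an amine nitrogen) in which benzyl gives way to 2-(dimethylamino)ethyl. Among the compounds with values here, no measured step makes this exchange. The nearest ones are large, with a 13-fold higher number from compound 1 to compound 3 (1.12 log units; beyond the scatter) and a 400-fold higher number from compound 2 to compound 3 (2.60 log units; beyond the scatter) both leaving benzyl(methyl)amino on the high side, and a 30-fold lower number from compound 1 to compound 2 (1.48 log units; beyond the scatter) showing how far the amine can move the number. A moderate drop is therefore expected, an estimated 2.7-fold lower number from compound 3 to compound 4 (0.43 log units; beyond the scatter) in this assay with wide uncertainty. For compound 4 the estimate is 15 mg/kg (expected range 2 mg/kg to 80 mg/kg).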

Compound 4, dose for half-maximal effect: 5 mg/kg
Compound 4: the middle estimate sits 3.0-fold (0.48 log units) above what was measured; the range from low to high includes it.
By their numbers in this assay, from the lowest: compound 2; then compounds 1 and 4 (each within the scatter of the next); then compound 3.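

In this assay, (dimethylamino)methyl in place of phenyl on a saturated chain carbon bound to an amine nitrogen gives an 8.0-fold lower number from compound 3 to compound 4 (0.90 log units; beyond the scatter), so at this position the number falls without the aromatic ring. The new amine still leaves a 50-fold higher number from compound 2 to compound 4 (1.70 log units; beyond the scatter), whereas a 1.7-fold higher number from compound 1 to compound 4 (0.22 log units; within the scatter) stays within the scatter, so it does not reach the low number of compound 2. Nothing available explains these steps. On these data alone, whether a longer chain carrying the dimethylamino group, or a pyrrolidine in its place, would move the number further stays open.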